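Side-chain change from compound 2 to compound 3

A few compounds are considered here, and "the series" means these few. Any claim that something is new, unique, unknown or untested is made for them only; others in the source may bear on it.

- compound 1 `CCCCCC(=O)NCC(=O)N(C)c1ccc(Cl)cc1C(=O)c1ccccc1Cl` gives 90 mg/kg
- compound 2 `CC(C)NCC(=O)NCC(=O)N(C)c1ccc(Cl)cc1C(=O)c1ccccc1Cl` gives 13 mg/kg

Among the compounds with values here, in a functional assay on the whole organism with Mus musculus as the target, in the rotarod test (on this read-out higher numbers stand for an effect only at larger amounts of compound and lower numbers for an effect already at smaller amounts), compound 2 stands at 13 mg/kg as the lower of the two numbers so far. The next structure is compound 3 `CC(NC(=O)CN)C(=O)N(C)c1ccc(Cl)cc1C(=O)c1ccccc1Cl` on the same shared core. The change is 1-(((aminomethyl)carbonyl)amino)ethyl in place of ((((isopropylamino)methyl)carbonyl)amino)methyl on a carbonyl carbon and puts 1-(((aminomethyl)carbonyl)amino)ethyl in place of ((((isopropylamino)methyl)carbonyl)amino)methyl on a carbonyl carbon.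

Within the data shown here, only one measured step bears on this: a 6.9-fold lower number from compound 1 to compound 2 (0.84 log units; beyond the scatter) with isopropylamino in place of butyl on a saturated chain carbon bound to a carbonyl carbon. That step is modest but beyond the scatter, and it shows that the number in this assay can respond to a change in this chain. Among the measured compounds shown here, no measured step covers the present exchange, so the data fix neither its size nor its direction. A step smaller than that one is expected, with a slight lean towards a higher number. The expected change is a 1.9-fold higher number from compound 2 to compound 3 (0.28 log units; within the scatter) on this estimate. Compound 3 is estimated at 25 mg/kg with an expected range from 8 mg/kg to 80 mg/kg in this read-out.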

Compound 3, dose for half-maximal effect: 8.5 mg/kg
Beside the measured number, compound 3's estimate is 2.9-fold (0.47 log units) above it; measured number inside the range.
By their numbers in this assay, from the lowest: compounds 3 and 2 (each within the scatter of the next); then compound 1.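

In this assay, 1-(((aminomethyl)carbonyl)amino)ethyl in place of ((((isopropylamino)methyl)carbonyl)amino)methyl on a carbonyl carbon gives a 1.5-fold lower number from compound 2 to compound 3 (0.18 log units; within the scatter), so this read-out does not tell the two side chains apart, although the entering one has 7 heavy atoms against 9 and no isopropyl group. The isopropyl group is therefore not needed to keep the number in this range, as the aminomethyl chain of compound 3 shows. The separation from the chain without an amine holds, with an 11-fold lower number from compound 1 to compound 3 (1.02 log units; beyond the scatter), and among the three compounds both amine-bearing side chains stand apart from the ((pentylcarbonyl)amino)methyl chain of compound 1, with none going against this. No measurement on hand gives a reason for these numbers.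

The step from compound 2 to compound 3 combines the loss of the isopropyl group with the change to a 1-substituted ethyl chain, and the compounds shown do not separate these two changes. Also open, going by these compounds, is how a dimethylamino group or a carboxylic acid at the end of this side chain would read in this assay.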